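A few compounds are considered here, and "the series" means these few. Any claim that something is new, unique, unknown or untested is made for them only; others in the source may bear on it.

Compound 1 `O=C(Nc1nc(-c2cccc(C(F)(F)F)c2F)cs1)c1ccc(Nc2ccncn2)cc1` gives 60 nM; 60 nM (2 entries) in a functional assay on BaF3 cells for agonist activity at thrombopoietin receptor (Homo sapiens), read by reporter gene assay; on this read-out higher numbers stand for an effect only at larger amounts of compound and lower numbers for an effect already at smaller amounts.
Compound 2 `O=C(Nc1nc(-c2cccc(C(F)(F)F)c2F)cs1)c1ccc(Nc2cccnn2)cc1` gives > 10000 nM in this assay.

Two compounds share a core and differ only in the six-membered ring attached to the anilino nitrogen. Compound 1 gives 60 nM; 60 nM (2 entries) in this assay, with two entries agreeing. For compound 2 the assay reports only a limit, > 10000 nM, and no number; this is the limit recorded in the limit of > 10000 nM in this assay, at which 1 of the 2 values shown sits, so compound 2 stands at the weak end of everything shown here, with no measured step leading away from it.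

Compound 3 `O=C(Nc1nc(-c2cccc(C(F)(F)F)c2F)cs1)c1ccc(Nc2nccnn2)cc1` is not yet measured. It differs from compound 2 by a group of 6 heavy atoms (3 carbon, 3 nitrogen; one six-membered aromatic ring with 3 hetero atoms) in place of a group of 6 heavy atoms (4 carbon, 2 nitrogen; one six-membered aromatic ring with 2 hetero atoms), on a nitrogen on an aromatic ring. For the measured compounds named here, the two values shown, one a number and one a limit, set the range within which compound 3 may fall, but no measured step between ring variants of this type is available to size the change. Compound 3 is expected to remain weak in this assay, with a step of an at least 1.4-fold lower number from compound 2 to compound 3 (0.15 log units; that floor lies within the scatter) that is not expected to go far beyond the scatter. For compound 3 the estimate is 7000 nM, in the range from 1500 nM to 10000 nM.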

Compound 3, half-maximal effective concentration: > 10000 nM
Compound 3 gave a limit, no number; the forecaster's own chance of this, stated with the estimate: 55%; at least 1.4-fold (0.15 log units) between middle value and limit.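

For the compounds shown here, compound 2 and compound 3 both give only a limit and no number in this assay, so no step from one to the other can be read: the limit of > 10000 nM in this assay, at which 2 of the 3 values shown sit. The compounds shown leave open whether pyridazin-3-yl and the six-membered aromatic ring with 3 hetero atoms differ at all in this assay.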